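A few compounds are considered here, and "the series" means these few. Any claim that something is new, unique, unknown or untested is made for them only; others in the source may bear on it.

Measured so far:
compound 1, `CN1CCN(c2nc(Cl)nc3c2ncn3Cc2ccc(C(=O)Nc3ccccc3N)cc2)CC1` — 55.1%
compound 2, `Nc1ccccc1NC(=O)/C=C/c1ccc(Cn2cnc3c(NC4CCCCC4)nc(Cl)nc32)cc1` — 24.9%

In a functional assay on NCI-H460 cells (Homo sapiens) for antiproliferative activity, read by CCK-8 assay, with a stated time of 72 h, tested at 8 uM (a higher number here means a stronger effect of the compound at the concentration tested, a lower number a weaker effect), compound 1 gives 55.1%, the higher of the two numbers shown. Compound 2 gives 24.9%, a reading that lies beyond the scatter below compound 1; the two compounds differ in more than one place, so the gap is not tied to any single change. Compound 3, `Nc1ccccc1NC(=O)c1ccc(Cn2cnc3c(Nc4ccccc4)nc(Cl)nc32)cc1`, differs from compound 1 in one place: anilino in place of 4-methylpiperazin-1-yl on an aromatic carbon. Going by the values given here, no pair measured here isolates such a change. Among the compounds with values here, compound 3 is expected to give 40% (range 20% to 60%), a step of a number 15.1 percentage points lower from compound 1 to compound 3 (beyond the scatter) estimated as a moderate downward move, given only that compound 2, which also carries an amino substituent at that position, gives 24.9%.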

Compound 3, a percentage reported as inhibition, at one concentration (the size of the read-out at that concentration, not a potency): 77.8%
Estimate against measurement, compound 3: 37.8 percentage points below; measured number above the stated range.
By their numbers in this assay, from the lowest: compound 2; then compound 1; then compound 3.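

In this assay, going by these compounds alone, anilino in place of 4-methylpiperazin-1-yl on this aromatic carbon gives a number 22.7 percentage points higher from compound 1 to compound 3 (beyond the scatter), the only change at this position that can be read on its own. It shows that the reading responds to the group at this carbon and that the 4-methylpiperazin-1-yl group is not needed for the effect at the tested concentration. Nothing available explains this step. The compounds shown leave open whether the aromatic ring or the linking amine nitrogen carries the step. N-methylanilino or benzyl at this carbon would help separate the two.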